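The compounds below may be only part of what the source reports. "The series", "measured", "known", "first", "only" and "open" are said of these compounds alone.

Measured compounds in a functional assay on MGC-803 cells (Homo sapiens) for cytotoxicity, read by MTT assay, with a stated time of 72 h; on this read-out lower numbers stand for stronger inhibition and higher numbers for weaker inhibition:
compound 1 `Cc1cc(N2CCCCC2)nc(SCc2nc3ccccc3[nH]2)n1` gives only a limit of the assay, > 100000 nM.
compound 2 `COc1ccccc1Nc1cc(C)nc(SCc2nc3ccccc3[nH]2)n1` gives 56200 nM.

Compound 2 holds the only number shown in this assay; the one other value is a limit (the limit of > 100000 nM in this assay, at which 1 of the 2 values shown sits). Going by the values given here, the single measured step, an at least 1.7-fold lower number from compound 1 to compound 2 (0.25 log units; that floor lies within the scatter), is the only evidence on how changes at this position move the read-out, and its floor lies within the scatter, so it fixes no size.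

Compound 3 `Cc1cc(N(C)Cc2ccccc2)nc(SCc2nc3ccccc3[nH]2)n1` differs from compound 2 by benzyl(methyl)amino in place of (2-methoxyphenyl)amino on an aromatic carbon. Among the compounds with values here, no measured step covers this exchange; the step from compound 1 to compound 2 shows only that an amine at this position can sit at the limit or give a weak number. The expectation for compound 3 in this assay is therefore a small step toward weaker inhibition, a 1.6-fold higher number from compound 2 to compound 3 (0.20 log units; within the scatter), with a real chance that only a limit is reported. Compound 3 is estimated at 90000 nM, between 35000 nM and 250000 nM.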

Compound 3, half-maximal inhibitory concentration: 31300 nM
The estimate for compound 3 lay 2.9-fold (0.46 log units) above the measured number, outside the stated range (below it).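

In this assay, the exchange of (2-methoxyphenyl)amino for benzyl(methyl)amino gives a 1.8-fold lower number from compound 2 to compound 3 (0.25 log units; within the scatter), so these two amines cannot be told apart, even though the entering group has 0 hydrogen-bond donors and the leaving group has 1. Going by these compounds alone, replacing piperidin-1-yl with benzyl(methyl)amino gives an at least 3.1-fold lower number from compound 1 to compound 3 (0.50 log units; beyond the scatter), the only step at this position that clears the scatter, showing that the choice of amine here can move the read-out. Compound 1 gives only a limit of the assay, so this step has a floor and no fixed size: the limit of > 100000 nM in this assay, at which 1 of the 3 values shown sits.

Open, going by these compounds, is whether benzylamino, with the hydrogen in place of the methyl on its nitrogen, would read level with compound 3. Also open, on these data alone, is whether a chlorine or a carboxylic acid on the benzyl ring would shift the number beyond the scatter.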